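The source may hold more compounds than are shown below. What is called first, only, known or untested is meant among the compounds shown, and "the series" means these compounds.

Compound 1 `CCCCNC(=O)Nc1cc2nc(C3CCCCC3)[nH]c2cc1N(CC)CC` gives > 100 ug/mL in an ADME assay on Vero cells (Chlorocebus sabaeus) for cytotoxicity, read by resazurin assay, with a stated time of 3 days (a lower number here means a stronger inhibitor, a higher number a weaker inhibitor), which is a limit of the assay rather than a number.
Compound 2 `CCCC(C)OC(=O)Nc1cc2nc(C3CCCCC3)[nH]c2cc1N(CC)CC` gives > 100 ug/mL in this assay, again a limit.

Compound 3 `CCc1ccc(C(=O)Nc2cc3nc(C4CCCCC4)[nH]c3cc2N(CC)CC)cc1` is not yet measured. It differs from compound 2 by 4-ethylphenyl in place of 1-methylbutoxy on a carbonyl carbon. Among the measured compounds shown here, the only measured step, a step that the two limits leave unreadable from compound 1 to compound 2, has no readable size, since both of its values sit at the limit of > 100 ug/mL in this assay, at which 2 of the 2 values shown sit. For the measured compounds named here, no measured step therefore points in either direction for compound 3. Compound 3 is expected to stay at or near the limit, with a step that the limit leaves unreadable from compound 2 to compound 3 estimated as no shift beyond the scatter. Compound 3 is estimated at 120 ug/mL, between 50 ug/mL and 300 ug/mL.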

Compound 3, half-maximal inhibitory concentration: > 100 ug/mL
Compound 3 gave a limit, no number (the forecaster's own chance of this, stated with the estimate: 70%); the middle value is on the limit's open side.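

Among the compounds shown here, compound 3 also gives a limit rather than a number, so no step among compound 1, compound 2 and compound 3 can be read in this assay here: the limit of > 100 ug/mL in this assay, at which 3 of the 3 values shown sit.
The compounds shown leave open whether any group on the carbonyl carbon gives a readable value in this assay at all.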